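Swapping a Cyanophenyl for a Benzyl on a Thiourea

The source may hold more compounds than are shown below. What is called first, only, known or untested is meant among the compounds shown, and "the series" means these compounds.

Of the compounds shown here, three have been tested in a functional assay on T98G cells (Homo sapiens) for inhibition, read by MTT assay, with a stated time of 72 h; on this read-out lower numbers stand for stronger inhibition and higher numbers for weaker inhibition. Compound 1 `O=[N+]([O-])c1cccc(NC(=S)NCc2cccc(Cl)c2)c1` gives 61000 nM, compound 3 `CC1(C)CC(NC(=O)NCc2ccccc2)c2cc(F)ccc2O1` gives 49000 nM, and compound 2 `CC1(C)CC(NC(=S)Nc2ccc(C#N)cc2)c2cc(F)ccc2O1` gives 19000 nM, the lowest of the three numbers and beyond the scatter from both others. The next compound, compound 4 `CC1(C)CC(NC(=S)NCc2ccccc2)c2cc(F)ccc2O1`, has not yet been tested in this assay. It differs from compound 2 in one place: benzyl in place of 4-cyanophenyl on an amide-type nitrogen. Going by the values given here, with no measured pair showing this same change, the expectation rests on the values of compound 2 and compound 3 alone, and compound 4 is expected to land between them, a step of a 1.8-fold higher number from compound 2 to compound 4 (0.27 log units; within the scatter) that is likely modest and in the weaker direction. Compound 4 is therefore estimated at 35000 nM, within a range of 15000 nM to 80000 nM.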

Compound 4, half-maximal inhibitory concentration: 40000 nM
Compound 4: the middle estimate sits 1.1-fold (0.06 log units) below what was measured; measured number inside the range.
By their numbers in this assay, from the lowest: compound 2; then compounds 4, 3 and 1 (each within the scatter of the next).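

In this assay, putting benzyl in place of 4-cyanophenyl on the amide-type nitrogen gives a 2.1-fold higher number from compound 2 to compound 4 (0.32 log units; beyond the scatter). Going by these compounds alone, this is the first comparison here in which only one place changes, and it shows that the group on this nitrogen affects the read-out, though modestly. Nothing measured here explains the step.

From the compounds shown here alone, it remains open whether a plain phenyl, a 4-methoxyphenyl or a longer chain such as phenethyl on this nitrogen would read closer to compound 2 or to compound 4. A single pair also cannot show whether the same change would have a similar effect on another core.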